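The source may hold more compounds than are shown below. What is called first, only, known or untested is meant among the compounds shown, and "the series" means these compounds.

Compound 3 `CCOC(=O)c1cnc(-c2ccc(Cl)cc2)nc1NN1C(=O)C=C(C)C1=O` holds the second highest of the three numbers measured in a functional assay on Jurkat cells for inhibition of nuclear factor NF-kappa-B complex (Homo sapiens) (on this read-out higher numbers stand for weaker inhibition and lower numbers for stronger inhibition), where compound 3 gives 300 nM. Compound 1 `CCOC(=O)c1cnc(-c2ccccc2)nc1NN1C(=O)C=C(C)C1=O` gives 100 nM, and compound 2 `CCOC(=O)c1cnc(-c2csc(C)n2)nc1NN1C(=O)C=C(C)C1=O` gives 8000 nM. Compound 4 `CCOC(=O)c1cnc(-c2ccc(Cl)s2)nc1NN1C(=O)C=C(C)C1=O` differs from compound 3 in one place: 5-chlorothiophen-2-yl in place of 4-chlorophenyl on an aromatic carbon. Among the measured compounds shown here, two measured steps bear on trading a six-membered aromatic ring of carbon only for a five-membered aromatic ring with hetero atoms: an 80-fold higher number from compound 1 to compound 2 (1.90 log units; beyond the scatter) and a 27-fold lower number from compound 2 to compound 3 (1.43 log units; beyond the scatter), both large and both against the five-membered ring. The ring entering compound 4 holds only 1 hetero atom, so a smaller loss than those is expected, but still one beyond the scatter. Compound 4 is therefore estimated at 2000 nM, within 600 nM to 8000 nM, an expected step of a 6.7-fold higher number from compound 3 to compound 4 (0.82 log units; beyond the scatter).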

Compound 4, half-maximal inhibitory concentration: 300 nM
Compound 4: middle estimate off by 6.7-fold (0.82 log units), on the high side, outside the stated range (below it).
By their numbers in this assay, from the lowest: compound 1; then compounds 3 and 4 (each within the scatter of the next); then compound 2.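

In this assay, 5-chlorothiophen-2-yl replaces 4-chlorophenyl with no change at the digits printed from compound 3 to compound 4 (within the scatter), so at this place, between two ring nitrogen atoms, a five-membered aromatic ring need not cost anything. Ring size alone therefore does not set the loss seen with 2-methyl-1,3-thiazol-4-yl, as a 27-fold lower number from compound 2 to compound 4 (1.43 log units; beyond the scatter) shows, and a 3.0-fold higher number from compound 1 to compound 4 (0.48 log units; beyond the scatter) leaves the unsubstituted phenyl still ahead. Nothing measured here explains these differences. Open, as far as these compounds go, is whether thiophen-2-yl without chloro would match phenyl. Also open, from the compounds shown here alone, is how a methoxy group or an amine in place of chloro on the thiophene would fare.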